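Diisopropylphenyl imidodicarbonates: chain change on the sulfur side

A few compounds are considered here, and "the series" means these few. Any claim that something is new, unique, unknown or untested is made for them only; others in the source may bear on it.

Compound 1 `CC(C)c1cccc(C(C)C)c1OC(=O)NC(=O)OCc1ccccc1` gives 77 nM in an assay on microsomes from intestine for inhibition of acyl-CoA:cholesterol acyltransferase (Oryctolagus cuniculus); a higher number here means a weaker inhibitor, a lower number a stronger inhibitor.
Compound 2 `CCCCCCCCOC(=O)NC(=O)Oc1c(C(C)C)cccc1C(C)C` gives 250 nM in this assay.
Compound 3 `CC(C)c1cccc(C(C)C)c1OC(=O)NC(=O)SCCc1ccccc1` gives 880 nM in this assay.

Compound 3 carries the highest number of the three; its steps to compound 2 and compound 1 are a 3.5-fold higher number from compound 2 to compound 3 (0.55 log units; beyond the scatter) and an 11-fold higher number from compound 1 to compound 3 (1.06 log units; beyond the scatter), both beyond the scatter.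

Compound 4 `CCCCCCCCCCSC(=O)NC(=O)Oc1c(C(C)C)cccc1C(C)C` differs from compound 3 as follows: octyl in place of phenyl on a saturated chain carbon, two bonds along the chain from a sulfur. Within the data shown here, the one measured step of this kind is on the oxygen side, where an alkyl chain replaced phenyl, a 3.2-fold higher number from compound 1 to compound 2 (0.51 log units; beyond the scatter). Transferred to the sulfur side, a similar modest rise in the number is expected, a 2.8-fold higher number from compound 3 to compound 4 (0.45 log units; beyond the scatter). Compound 4 is therefore estimated at 2500 nM, with a range of 900 nM to 7000 nM.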

Compound 4, half-maximal inhibitory concentration: 130 nM
Compound 4: middle estimate off by 19-fold (1.28 log units), on the high side, and the stated range ends above it.
By their numbers in this assay, from the lowest: compounds 1, 4 and 2 (each within the scatter of the next, the first and the last beyond it); then compound 3.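

On the sulfur side, octyl in place of phenyl lowers the number in this assay (a 6.8-fold lower number from compound 3 to compound 4 (0.83 log units; beyond the scatter)), while heptyl in place of phenyl on the oxygen side runs the other way (a 3.2-fold higher number from compound 1 to compound 2 (0.51 log units; beyond the scatter)). A phenyl-to-alkyl change therefore has no common direction across these two pairs, and the oxygen-side step does not carry over to the sulfur side. Nothing available bears on the reason for this reversal.

Open, going by these compounds, is how the number on the sulfur side moves with chain length, for example with a hexyl or a dodecyl chain. Also open, on these data alone, is what an amine at the chain end would do.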